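Replacing 1-(pyridin-2-yl)ethyl with thiophen-2-yl in compound 3

The compounds below may be only part of what the source reports. "The series", "measured", "known", "first", "only" and "open" are said of these compounds alone.

Three compounds have values in a functional assay (blood) for inhibition, with Homo sapiens as the target (on this read-out higher numbers stand for weaker inhibition and lower numbers for stronger inhibition), so far:
compound 1 (`CC(C)(C)Sc1c(CC(C)(C)C(=O)O)n(Cc2ccc(Cl)cc2)c2ccc(OCc3ccc4cc(F)ccc4n3)cc12`) gives 880 nM
compound 2 (`COc1ccc2nc(COc3ccc4c(c3)c(SC(C)(C)C)c(CC(C)(C)C(=O)O)n4Cc3ccc(Cl)cc3)sc2c1`) gives 670 nM
compound 3 (`C[C@H](COc1ccc2c(c1)c(SC(C)(C)C)c(CC(C)(C)C(=O)O)n2Cc1ccc(Cl)cc1)c1ccccn1`) gives 470 nM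

Compound 3, at 470 nM, cannot be ranked against the other two. The steps that reach it are a 1.9-fold lower number from compound 1 to compound 3 (0.27 log units; within the scatter) and a 1.4-fold lower number from compound 2 to compound 3 (0.15 log units; within the scatter) in size.

Compound 4 (`CC(C)(C)Sc1c(CC(C)(C)C(=O)O)n(Cc2ccc(Cl)cc2)c2ccc(OCc3cccs3)cc12`) is still unmeasured. It carries thiophen-2-yl in place of 1-(pyridin-2-yl)ethyl on a saturated chain carbon bound to an oxygen on an aromatic ring. With a 1.3-fold lower number from compound 1 to compound 2 (0.12 log units; within the scatter) added to those two steps, every swap seen so far at this place stayed within the scatter, so no step beyond the scatter is expected in this assay here. Going by the values given here, no measured compound carries thiophen-2-yl, which leaves this expectation uncertain. The expected size is a 1.4-fold higher number from compound 3 to compound 4 (0.14 log units; within the scatter) by this estimate. For compound 4 the estimate is 650 nM as the expected value, with 280 nM to 1500 nM as its range.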

Compound 4, half-maximal inhibitory concentration: > 3000 nM
Compound 4 ended at the assay's limit (the forecaster's own chance of this, stated with the estimate: 2%); middle value at least 4.6-fold (0.66 log units) from the limit.
By their numbers in this assay, from the lowest: compounds 3, 2 and 1 (each within the scatter of the next). At a limit, above all of these: compound 4.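

In this assay, compound 4 gives > 3000 nM, which is a limit of the assay and not a number. The earlier swaps at this place all stayed within the scatter, whereas this one gives an at least 6.3-fold higher number from compound 3 to compound 4 (0.80 log units; beyond the scatter), an at least 4.4-fold higher number from compound 2 to compound 4 (0.65 log units; beyond the scatter) and an at least 3.4-fold higher number from compound 1 to compound 4 (0.53 log units; beyond the scatter), all beyond the scatter. The group on this saturated chain carbon bound to an oxygen on an aromatic ring therefore cannot be exchanged freely, and thiophen-2-yl, with its 5 heavy atoms and five-membered aromatic ring, is the one group shown that breaks from the other three.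

This swap also removes the defined stereocentre and changes the hetero atom, so the compounds shown cannot say which of these differences matters, and the limit hides how large the steps really are. A plain phenyl ring at this place, or a thiophen-2-yl carrying a methoxy group, could help separate ring size from the rest.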